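Pyridinyl in place of the halophenyl: compound 4

The source may hold more compounds than are shown below. What is called first, only, known or untested is meant among the compounds shown, and "the series" means these compounds.

Compound 1 `Nc1scc(CN2CCN(c3ccc(Cl)cc3Cl)CC2)c1C(=O)c1ccc(Cl)cc1` gives -11% in a functional assay on CHO cells with adenosine receptor A1 (Homo sapiens) as the target, read by cAMP accumulation and immunoassay, with a stated time of 6 min, tested at 0.1 uM; a higher number here means a weaker effect of the compound at the concentration tested, a lower number a stronger effect. Compound 2 `Nc1scc(CN2CCN(c3ccc(F)cc3Cl)CC2)c1C(=O)c1ccc(Cl)cc1` gives -6.2% in this assay, and compound 3 `Nc1scc(CN2CCN(c3ccc(Cl)c(C(F)(F)F)c3)CC2)c1C(=O)c1ccc(Cl)cc1` gives -12%. Compound 2 has the highest of the three numbers, but its gap to compound 1 and its gap to compound 3 both lie within the scatter, so no order among the three can be read from these data. For the measured compounds named here, the steps so far are a number 4.8 percentage points higher from compound 1 to compound 2 (within the scatter), a number 1 percentage points lower from compound 1 to compound 3 (within the scatter) and a number 5.8 percentage points lower from compound 2 to compound 3 (within the scatter); each exchanges one halogenated phenyl for another on the ring nitrogen, and none moves the read-out beyond the scatter.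

Compound 4 `Nc1scc(CN2CCN(c3ccncc3)CC2)c1C(=O)c1ccc(Cl)cc1` differs from compound 2 as follows: pyridin-4-yl in place of 2-chloro-4-fluorophenyl on an amine nitrogen in a ring. Going by the values given here, no measured step replaces a phenyl by a pyridinyl, so the steps above bear on compound 4 only in showing that the group on this nitrogen has so far left this assay flat. A step of a number 1.8 percentage points lower from compound 2 to compound 4 (within the scatter) is therefore expected, none beyond the scatter. For compound 4 the estimate in this assay is -8%, with a range from -25% to 10%.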

Compound 4, a percentage reported as activity, at one concentration (the size of the read-out at that concentration, not a potency): 1.4%
Compound 4: the middle estimate sits 9.4 percentage points below what was measured, and the stated range covers the measured number.
By their numbers in this assay, from the lowest: compounds 3, 1, 2 and 4 (each within the scatter of the next, the first and the last beyond it).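

In this assay, for the compounds shown here, pyridin-4-yl on the amine nitrogen in a ring gives the first steps at this position that pass the scatter: a number 13.4 percentage points higher from compound 3 to compound 4 (beyond the scatter) and a number 12.4 percentage points higher from compound 1 to compound 4 (beyond the scatter) are both modest and both point to a weaker effect at the concentration tested. The group on this nitrogen is therefore not wholly without influence on the read-out, but compound 2 goes against a clean split between pyridin-4-yl and the halogenated phenyls, with a number 7.6 percentage points higher from compound 2 to compound 4 (within the scatter) leaving compound 4 not separable from it. Nothing at hand accounts for these steps.

An unsubstituted phenyl on this nitrogen would help separate the part played by the ring nitrogen of pyridin-4-yl from the part played by the loss of the halogens. A pyridin-3-yl would test whether the place of that ring nitrogen matters, and a read-out at one concentration leaves potency open.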